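Swapping an Isopropyl Amide for an Oxane Ring

The source may report more compounds than this note shows. Statements on the series, on what has been measured and on what is new or still open speak of the compounds shown alone.

Measured so far:
compound 1, `CC(C)C(=O)N1CCC(NC(=O)Nc2ccc(C(F)(F)F)c(F)c2)CC1`, 4.4
compound 2, `O=C(Nc1ccc(C(F)(F)F)cc1)NC1CCN(C(=O)C2CCOC2)CC1`, 3.16
compound 3, `O=C(Nc1ccc(C(F)(F)F)cc1)NC1CCN(C(=O)C2CCOCC2)CC1`, 3.16

Of the compounds shown here, three have been measured in a physicochemical assay for lipophilicity, read by HPLC, with a stated time of 90 min, tested at 100 uM; a lower number here means a more polar compound, a higher number a more lipophilic compound. Compound 1 gives the highest of the three numbers, 4.4, well beyond the scatter above the other two. For the measured compounds named here, compound 2 and compound 3 share the same value, and the one single-point step recorded between them, no change at the digits printed from compound 2 to compound 3 (within the scatter), shows that an oxan-4-yl and an oxolan-3-yl on the carbonyl carbon give the same number.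

Compound 4, `O=C(Nc1ccc(C(F)(F)F)c(F)c1)NC1CCN(C(=O)C2CCCOC2)CC1`, has not yet been measured. It differs from compound 1 in one place: oxan-3-yl in place of isopropyl on a carbonyl carbon. Going by the values given here, no measured step covers exactly this change. Among the compounds with values here, compound 2 and compound 3 differ from compound 1 in more than one place, so their values show only that compounds carrying an oxygen-containing ring on the carbonyl carbon sit clearly lower in this assay than compound 1. On that basis the step is expected to go downward by a moderate amount, and a number 0.90 log units lower from compound 1 to compound 4 (beyond the scatter) is the size expected. Compound 4 is therefore estimated at 3.5, with a likely range from 3 to 4.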

Compound 4, partition coefficient: 3.84
Beside the measured number, compound 4's estimate is 0.34 log units below it; measured number inside the range.
By their numbers in this assay, from the lowest: compounds 2 and 3 (each within the scatter of the next); then compound 4; then compound 1.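

In this assay, the exchange of isopropyl for oxan-3-yl on the carbonyl carbon gives a number 0.56 log units lower from compound 1 to compound 4 (beyond the scatter), and this is the one step shown at this position in which nothing else in the structure differs. Compounds 2 and 3 could not give this reading, as each differs from compound 1 in more than one place, so the fall can now be tied to this single exchange of groups on the shared core. The exchange brings in a six-membered ring with one oxygen and more carbon than isopropyl has, and the number still goes down, although no measurement shown here accounts for the size of this step or says which part of the new group is responsible.

On these data alone, whether oxolan-3-yl or oxan-4-yl would give a similar step on the core of compound 1 remains open. Also open, as far as these compounds go, is how a plain cyclohexyl ring, a longer carbon chain, an amine or a carboxylic acid on the same carbonyl carbon would read in this assay, and so how far this single step extends to other groups.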